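Methyl on the sulfonyl ring and cytotoxicity in liver cells

This account rests on a few compounds, and the source may have more. Where it says the series, first, only, none or still open, it means among the compounds named here.

The measured compounds:
compound 1, `O=C1/C(=C/c2ccncc2)CN(S(=O)(=O)c2ccccc2)C/C1=C\c1ccccc1F`: 15900 nM
compound 2, `Cc1ccc(S(=O)(=O)N2C/C(=C\c3ccncc3)C(=O)/C(=C/c3ccccc3F)C2)cc1`: > 20000 nM
compound 3, `O=C1/C(=C/c2cccnc2)CN(S(=O)(=O)c2ccccc2)C/C1=C\c1ccccc1C(F)(F)F`: 12500 nM

All three were tested in an ADME assay on L02 cells (Homo sapiens) for cytotoxicity, read by MTT assay, with a stated time of 24 h (a lower number here means a stronger inhibitor, a higher number a weaker inhibitor), and the value of compound 2 is a limit of the assay, not a number. Compound 4, `Cc1ccc(S(=O)(=O)N2C/C(=C\c3cccnc3)C(=O)/C(=C/c3ccccc3C(F)(F)F)C2)cc1`, has not yet been measured in this assay.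

Compound 1 and compound 2 differ in one place: methyl in place of hydrogen on an aromatic carbon. That change gave an at least 1.2-fold higher number from compound 1 to compound 2 (0.09 log units; that floor lies within the scatter), and the size of the step is known only as a floor, since the value of compound 2 sits at the limit of > 20000 nM in this assay, at which 1 of the 3 values shown sits.

Compound 3 shares its core with compound 1 but differs from it in more than one place, and the difference between the two cores is not broken down here. In this assay compound 3 gives 12500 nM, which lies within the usual scatter of the value of compound 1.

Compound 3 and compound 4 differ by methyl in place of hydrogen on an aromatic carbon, the same change as from compound 1 to compound 2, on the same place. For the measured compounds named here, from compound 3 to compound 4 a step of about a 1.6-fold higher number from compound 3 to compound 4 (0.20 log units; within the scatter) is expected in this assay, resting on an at least 1.2-fold higher number from compound 1 to compound 2 (0.09 log units; that floor lies within the scatter) as the one earlier example. Compound 4 is therefore estimated at 20000 nM, with a likely range from 10000 nM to 40000 nM, and the assay may well report only a limit for compound 4.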

Compound 4, half-maximal inhibitory concentration: 12300 nM
For compound 4 the middle estimate is 1.6-fold (0.21 log units) above the measured one; the measured number falls inside the stated range.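

In this assay, putting a methyl on the phenylsulfonyl group of the core of compound 3, the change from phenyl to 4-methylphenyl, gave a 1.0-fold lower number from compound 3 to compound 4 (0.01 log units; within the scatter), and on this core the change therefore leaves no mark that can be told from the usual scatter. Set beside the earlier example, the two steps compare only this far: the same change on two cores in this assay, an at least 1.2-fold higher number (0.09 log units; that floor lies within the scatter) from compound 1 to compound 2 and a 1.0-fold lower number (0.01 log units; within the scatter) from compound 3 to compound 4; the limit leaves it open whether they differ. This does not show that the change carries over in the same way from one core to the other, as the reading of compound 2 is a limit of the assay and not a number: the limit of > 20000 nM in this assay, at which 1 of the 4 values shown sits.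

The compounds shown carry only hydrogen or methyl at this place, which leaves open how a group such as an amine, a carboxylic acid or a longer chain would read in this assay. Also open, as far as these compounds go, is whether the methyl would behave the same way on further cores, and which of the several differences between the core of compound 1 and the core of compound 3 would matter if the two steps did turn out to differ.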